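Aryl Amide Swaps on a Shared Core

The source may report more compounds than this note shows. Statements on the series, on what has been measured and on what is new or still open speak of the compounds shown alone.

Measured in a functional assay on HCC1937 cells (Homo sapiens) for antiproliferative activity, read by CCK-8 assay, with a stated time of 72 h; on this read-out higher numbers stand for weaker inhibition and lower numbers for stronger inhibition:
compound 1, `O=C(Nc1cccc(-c2oc3cc(-c4ccc(F)cc4)ccc3c(=O)c2O)c1)c1ccc(F)cc1F`, gives 6980 nM
compound 2, `Cc1ccccc1C(=O)Nc1cccc(-c2oc3cc(-c4ccc(F)cc4)ccc3c(=O)c2O)c1`, gives 9900 nM
compound 3, `COc1ccc(C(=O)Nc2cccc(-c3oc4cc(-c5ccc(F)cc5)ccc4c(=O)c3O)c2)c(F)c1`, gives 24500 nM

Compound 2 sits between the other two on these numbers. The smaller gap is a 1.4-fold higher number from compound 1 to compound 2 (0.15 log units; within the scatter), so the two are not separated; its gap to compound 3 is a 2.5-fold higher number from compound 2 to compound 3 (0.39 log units; beyond the scatter), a modest but real difference. Compound 1 to compound 3 shows a 3.5-fold higher number from compound 1 to compound 3 (0.55 log units; beyond the scatter).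

Compound 4, `O=C(Nc1cccc(-c2oc3cc(-c4ccc(F)cc4)ccc3c(=O)c2O)c1)c1ccc(Cl)nc1`, is not yet measured. Relative to compound 2 it carries the change (6-chloropyridin-3-yl in place of 2-methylphenyl on a carbonyl carbon). Going by the values given here, two measured steps bear on it, both swaps of the aryl group on the carbonyl carbon: a 1.4-fold higher number from compound 1 to compound 2 (0.15 log units; within the scatter), which stayed within the scatter, and a 2.5-fold higher number from compound 2 to compound 3 (0.39 log units; beyond the scatter), which moved the number modestly higher. On that footing the expected step in this assay is small, perhaps a slight rise in the number, with no firm reason to expect movement beyond the scatter; the expected step is a 1.0-fold higher number from compound 2 to compound 4 (0.00 log units; within the scatter). Compound 4 is therefore estimated at 10000 nM, with a range from 4500 nM to 22000 nM.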

Compound 4, half-maximal inhibitory concentration: 7550 nM
Compound 4: the middle estimate sits 1.3-fold (0.12 log units) above what was measured; the range from low to high includes it.
By their numbers in this assay, from the lowest: compounds 1, 4 and 2 (each within the scatter of the next); then compound 3.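

In this assay, going by these compounds alone, compound 4 places on the carbonyl carbon a ring with a hetero atom, 6-chloropyridin-3-yl, whereas the aryl rings of the earlier compounds are of carbon only, and this change does not separate it from two of them, with a 1.3-fold lower number from compound 2 to compound 4 (0.12 log units; within the scatter) and a 1.1-fold higher number from compound 1 to compound 4 (0.03 log units; within the scatter) as the steps. The step to the third, a 3.2-fold lower number from compound 3 to compound 4 (0.51 log units; beyond the scatter) in the same read-out, is modest but real, so compound 3, with its 2-fluoro-4-methoxyphenyl group, now stands apart from all three other aryl amides and is the weakest of the four, while this position has so far tolerated a pyridine ring as well as the 2-methylphenyl and 2,4-difluorophenyl groups. Nothing among the available data accounts for these numbers.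

The ring nitrogen and the chlorine enter together in compound 4, so the compounds shown cannot say what either does alone. They also leave open how an amine or a carboxylic acid on this ring would read out, or how a saturated alkyl chain would do in place of the ring on the carbonyl carbon.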